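The compounds below may be only part of what the source reports. "The series", "measured", "known", "first", "only" and "open" are said of these compounds alone.

Measured so far:
compound 1, `CCOc1ccccc1N1CCN(CCCNc2ncccc2C(=O)N(C)C)CC1` — 0.501 nM
compound 2, `Cc1ccccc1N1CCN(CCCNc2ncccc2C(=O)N(C)C)CC1` — 2 nM

For the measured compounds named here, in a functional assay for antagonist activity at Alpha-1A adrenergic receptor (Oryctolagus cuniculus) (a lower number here means tighter binding, a higher number weaker binding), compound 2 stands at the higher of the two numbers; its only neighbour is compound 1, and the change from it, methyl in place of ethoxy on an aromatic carbon, reads a 4.0-fold higher number from compound 1 to compound 2 (0.60 log units; beyond the scatter). Compound 3, `CCCc1ccccc1N1CCN(CCCNc2ncccc2C(=O)N(C)C)CC1`, has not yet been measured. It differs from compound 2 by ethyl in place of hydrogen on a saturated chain carbon bound to an aromatic carbon. Going by the values given here, no measured step makes exactly this change; the only step that bears on it is the one from compound 1 to compound 2, in which the compound carrying the group with more atoms at that aromatic carbon gave the lower number. On that single precedent the step from compound 2 to compound 3 is expected to be a 1.8-fold lower number from compound 2 to compound 3 (0.26 log units; within the scatter), a small move downward that may not clear the scatter. Compound 3 is therefore estimated at 1.1 nM, with a range from 0.3 nM to 4 nM.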

Compound 3, dissociation constant: 0.2 nM
The estimate for compound 3 lay 5.5-fold (0.74 log units) above the measured number, outside the stated range (below it).
By their numbers in this assay, from the lowest: compound 3; then compound 1; then compound 2.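

In this assay, ethyl in place of hydrogen on a saturated chain carbon bound to an aromatic carbon, which turns methyl into propyl, reads a 10-fold lower number from compound 2 to compound 3 (1.00 log units; beyond the scatter). This shows that extending the carbon chain at this place can lower the number well beyond the scatter. Swapping ethoxy for propyl reads a 2.5-fold lower number from compound 1 to compound 3 (0.40 log units; beyond the scatter), so among these three compounds the lowest number belongs to the group without the ether oxygen, and that oxygen is not required for a low number here.

Nothing measured here accounts for these steps. The compounds shown leave open whether a butyl or longer chain would lower the number further or reverse the trend, and whether a branched isopropyl group would match propyl.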